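The source may report more compounds than this note shows. Statements on the series, on what has been measured and on what is new or still open speak of the compounds shown alone.

The measured compounds in a functional assay on HeLa cells (Homo sapiens) for inhibition, read by MTT assay, with a stated time of 72 h (a lower number here means a stronger inhibitor, a higher number a weaker inhibitor), are:

compound 1, `Cc1noc(C)c1-c1cnc(N)c(Oc2ccc(C(=O)Nc3cccc(Cl)n3)cc2)n1`, with 25500 nM
compound 2, `Cc1noc(C)c1-c1cnc(N)c(Oc2ccc(C(=O)Nc3ccc(Cl)cn3)cc2)n1`, with 19200 nM
compound 3, `Cn1cc(-c2cnc(N)c(Oc3ccc(C(=O)Nc4cccc(Cl)n4)cc3)n2)cn1`, with 38200 nM

Compound 4, `Cn1cc(-c2cnc(N)c(Oc3ccc(C(=O)Nc4ccc(Cl)cn4)cc3)n2)cn1`, has not yet been measured in this assay.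

The change from compound 3 to compound 4 is 5-chloropyridin-2-yl in place of 6-chloropyridin-2-yl on an amide-type nitrogen. The same change has already been made once among the measured compounds, from compound 1 to compound 2, where it reads (5-chloropyridin-2-yl in place of 6-chloropyridin-2-yl on an amide-type nitrogen); in this assay it gave a 1.3-fold lower number from compound 1 to compound 2 (0.12 log units; within the scatter). The place of the change is described in the same words in both pairs, so it can be called the same change, made on a different core.

The two cores differ by 1-methyl-1H-pyrazol-4-yl in place of 3,5-dimethyl-1,2-oxazol-4-yl on an aromatic carbon. In this assay this difference gave a 1.5-fold higher number from compound 1 to compound 3 (0.18 log units; within the scatter), so compound 1 and compound 3 sit close to one another in this assay.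

For the measured compounds named here, with only one earlier instance of the change to go on, the expectation for compound 4 rests on compound 3 at 38200 nM and on the earlier step of a 1.3-fold lower number from compound 1 to compound 2 (0.12 log units; within the scatter). On that basis the step from compound 3 to compound 4 is expected to be about a 1.3-fold lower number from compound 3 to compound 4 (0.10 log units; within the scatter). Compound 4 is therefore estimated at 30000 nM in this assay. The range for compound 4 is expected to run from 15000 nM to 60000 nM.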

Compound 4, half-maximal inhibitory concentration: 21500 nM
Estimate against measurement, compound 4: 1.4-fold (0.14 log units) above; the measured number falls inside the stated range.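

In this assay, 5-chloropyridin-2-yl in place of 6-chloropyridin-2-yl on the amide-type nitrogen gives a 1.8-fold lower number from compound 3 to compound 4 (0.25 log units; within the scatter), and this step agrees with its earlier counterpart on the other core: the same change on two cores in this assay, a 1.3-fold lower number (0.12 log units; within the scatter) from compound 1 to compound 2 and a 1.8-fold lower number (0.25 log units; within the scatter) from compound 3 to compound 4, 1.3-fold (0.13 log units) apart, within the scatter of two such steps. The second change, 1-methyl-1H-pyrazol-4-yl in place of 3,5-dimethyl-1,2-oxazol-4-yl on the aromatic carbon, gives a 1.1-fold higher number from compound 2 to compound 4 (0.05 log units; within the scatter), and it too stays close to its earlier counterpart: the same change on two cores in this assay, a 1.5-fold higher number (0.18 log units; within the scatter) from compound 1 to compound 3 and a 1.1-fold higher number (0.05 log units; within the scatter) from compound 2 to compound 4, 1.3-fold (0.13 log units) apart, within the scatter of two such steps. The four compounds therefore show no sign that either change reads differently from one core to the other, but every step lies within the scatter, so they do not show that either change has a real effect in this assay, and two cores cannot show that such agreement would extend to a third.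

The compounds shown leave open whether a different group in place of the chlorine on the pyridine, such as a methoxy group, a nitrile or a carboxylic acid, would give a step beyond the scatter. Going by these compounds, it also remains open whether an amine or a longer chain in place of the 1-methyl-1H-pyrazol-4-yl or 3,5-dimethyl-1,2-oxazol-4-yl group on the aromatic carbon would do so.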